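Chloro in Place of Methylsulfanyl: An Expected Small Step

The compounds below may be only part of what the source reports. "The series", "measured", "known", "first", "only" and "open" are said of these compounds alone.

Measured compounds:
compound 1 `CCCc1cc(N)c2cc(NC(=O)/C=C/c3ccc(Br)cc3)ccc2n1` 93 nM
compound 2 `CCCc1cc(N)c2cc(NC(=O)/C=C/c3ccc(C(C)C)cc3)ccc2n1` 520 nM
compound 3 `CCCc1cc(N)c2cc(NC(=O)/C=C/c3ccc(SC)cc3)ccc2n1` 71 nM

In a functional assay on HEK293 cells for activation of melanin-concentrating hormone receptor 1 (Homo sapiens), read by inositol phosphate accumulation (a higher number here means that more compound is needed for the effect, a lower number that less compound is needed), compound 3 gives the lowest of the three numbers, but the step between it and its nearest neighbour is only a 1.3-fold lower number from compound 1 to compound 3 (0.12 log units; within the scatter), so the two cannot be ranked against each other. Only compound 2 stands clearly apart: a 7.3-fold lower number from compound 2 to compound 3 (0.86 log units; beyond the scatter) and a 5.6-fold higher number from compound 1 to compound 2 (0.75 log units; beyond the scatter).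

Compound 4 `CCCc1cc(N)c2cc(NC(=O)/C=C/c3ccc(Cl)cc3)ccc2n1` is not yet measured. It differs from compound 3 by chloro in place of methylsulfanyl on an aromatic carbon.

Going by the values given here, no measured step involves chloro itself. The nearest guide is the bromo of compound 1, whose exchange for methylsulfanyl gave a 1.3-fold lower number from compound 1 to compound 3 (0.12 log units; within the scatter), a change inside the usual scatter. The only large steps shown, to and from the isopropyl of compound 2, concern a different group and do not bear directly on this change.

Compound 4 is therefore expected to land close to compound 3, with a step of a 1.5-fold higher number from compound 3 to compound 4 (0.19 log units; within the scatter), not beyond the scatter. The estimate for compound 4 is 110 nM, with a range from 45 nM to 280 nM.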

Compound 4, half-maximal effective concentration: 96 nM
Compound 4: middle estimate off by 1.1-fold (0.06 log units), on the high side; the measured number falls inside the stated range.
By their numbers in this assay, from the lowest: compounds 3, 1 and 4 (each within the scatter of the next); then compound 2.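

In this assay, chloro joins bromo and methylsulfanyl as a third group at this position that cannot be told apart from the others: a 1.4-fold higher number from compound 3 to compound 4 (0.13 log units; within the scatter), and a 1.0-fold higher number from compound 1 to compound 4 (0.01 log units; within the scatter). Going by these compounds alone, the earlier compounds showed only one such pair, whereas this result shows that going from the two heavy atoms of methylsulfanyl to the single chlorine leaves the number within the scatter. Isopropyl remains the only group here that stands apart, now also against chloro, with a 5.4-fold lower number from compound 2 to compound 4 (0.73 log units; beyond the scatter).

No measurement is at hand that could explain why isopropyl alone separates from the other three groups. The compounds shown also leave open whether this close grouping extends to other groups at the same position, such as fluoro, an amine, a carboxylic acid or a longer chain.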